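Changing the Aryl Group on the Ring Nitrogen: Compound 4

A few compounds are considered here, and "the series" means these few. Any claim that something is new, unique, unknown or untested is made for them only; others in the source may bear on it.

Compound 1 `N#CC1=C(N)Oc2c(N)cc3nc4ccccc4nc3c2C12C(=O)N(Cc1cnnn1-c1cccc(C(F)(F)F)c1)c1ccccc12` gives 18900 nM in a functional assay on HCT-116 cells (Homo sapiens) for antiproliferative activity, read by MTT assay, with a stated time of 48 h; on this read-out higher numbers stand for weaker inhibition and lower numbers for stronger inhibition.
Compound 2 `CCOc1ccc(-n2nncc2CN2C(=O)C3(C(C#N)=C(N)Oc4c(N)cc5nc6ccccc6nc5c43)c3ccccc32)cc1` gives > 50000 nM in this assay, which is a limit of the assay and not a number.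
Compound 3 `Cc1ccc(-n2nncc2CN2C(=O)C3(C(C#N)=C(N)Oc4c(N)cc5nc6ccccc6nc5c43)c3ccccc32)cc1Cl` gives > 50000 nM in this assay, again a limit of the assay.

Compound 3 therefore stands at the edge of what this assay can report, and it shares that position with one other compound, since (the limit of > 50000 nM in this assay, at which 2 of the 3 values shown sit). The change that leads to compound 4 `Cc1cc(C)c(-n2nncc2CN2C(=O)C3(C(C#N)=C(N)Oc4c(N)cc5nc6ccccc6nc5c43)c3ccccc32)c(C)c1` is 2,4,6-trimethylphenyl in place of 3-chloro-4-methylphenyl on an aromatic nitrogen. Two measured steps alter the same aryl group on the same nitrogen. From compound 1 to compound 3 the shift was an at least 2.6-fold higher number from compound 1 to compound 3 (0.42 log units; beyond the scatter), and the step that the two limits leave unreadable from compound 2 to compound 3 cannot be sized because both ends are limits. Only compound 1 reached a numerical value, and neither replacement aryl group did; the data give no direction for a third aryl group of this kind. Compound 4 is expected to stay at or beyond the limit, so its estimate is 60000 nM, ranging from 20000 nM to 200000 nM. The expected step is a step that the limit leaves unreadable from compound 3 to compound 4, which is not readable as a change beyond the scatter.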

Compound 4, half-maximal inhibitory concentration: > 50000 nM
Compound 4 gave a limit, no number; the forecaster's own chance of this, stated with the estimate: 65%; the middle value does not contradict the limit.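

Going by these compounds alone, with 2,4,6-trimethylphenyl on the aromatic nitrogen, a third replacement for 3-(trifluoromethyl)phenyl has failed to give a numerical value, so this outcome is not confined to the two earlier replacements, and the one readable step is an at least 2.6-fold higher number from compound 1 to compound 4 (0.42 log units; beyond the scatter). The steps from compound 2 and from compound 3 to compound 4 cannot be read: both ends of each step are limits, so these three compounds cannot be placed in any order. Compound 1 alone stands apart from the limit, which now covers all the other compounds shown: the limit of > 50000 nM in this assay, at which 3 of the 4 values shown sit.

On these data alone, whether the numerical value of compound 1 depends on the trifluoromethyl group itself stays open, and an unsubstituted phenyl ring or a phenyl ring bearing a single fluorine or a nitrile would speak to that. Equally open, as far as these compounds go, is how a phenyl ring carrying an amine or a carboxylic acid, or a longer alkyl chain in place of the aryl group, would read in this assay.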